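The source may hold more compounds than are shown below. What is called first, only, known or untested is meant among the compounds shown, and "the series" means these compounds.

Compound 1 `CCN1CCN(c2cc(C)c3cc(NC(=O)c4cccnc4)ccc3n2)CC1`: 26600 nM
Compound 2 `Cc1cc(N(C)C)nc2ccc(NC(=O)c3ccc(Cl)c(Cl)c3)cc12`: 33300 nM
Compound 3 `Cc1cc(N2CCN(C(C)C)CC2)nc2ccc(NC(=O)c3ccc(Cl)c(Cl)c3)cc12`: 1710 nM

These three compounds were tested in a functional assay on MCF7 cells (Homo sapiens) for antiproliferative activity, read by MTT assay, with a stated time of 72 h; a higher number here means a weaker inhibitor, a lower number a stronger inhibitor. On the numbers shown, compound 1 stands second highest of the three with 26600 nM. Compound 2, at 33300 nM, lies within the usual scatter of compound 1, so the two cannot be told apart, whereas compound 3 at 1710 nM sits well below both. Within the data shown here, the only step between compounds that differ in one place is a 19-fold lower number from compound 2 to compound 3 (1.29 log units; beyond the scatter), a change of the amine on the shared core.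

Compound 4 `CCN1CCN(c2cc(C)c3cc(NC(=O)c4ccccc4OC)ccc3n2)CC1` arises from compound 1 by a change in another part of the molecule: 2-methoxyphenyl in place of pyridin-3-yl on a carbonyl carbon. The amine on the shared core, which moved in the step from compound 2 to compound 3, is the same in compound 1 and compound 4. Among the measured compounds shown here, no measured pair differs at the carbonyl carbon, so the one measured step does not bear on this change, and the data give no ground to expect a shift in either direction. The expected step is therefore no change at the digits printed from compound 1 to compound 4 (within the scatter), within the scatter. In this assay compound 4 is estimated to give 26600 nM, in a range from 9000 nM to 80000 nM.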

Compound 4, half-maximal inhibitory concentration: 13200 nM
The estimate for compound 4 lay 2.0-fold (0.30 log units) above the measured number; measured number inside the range.
By their numbers in this assay, from the lowest: compound 3; then compounds 4, 1 and 2 (each within the scatter of the next, the first and the last beyond it).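

In this assay, among these compounds, the exchange on the carbonyl carbon gives a 2.0-fold lower number from compound 1 to compound 4 (0.30 log units; within the scatter), the first measured step at this place, and it lies within the scatter. With the amine of compound 1 held the same, one six-membered aromatic ring with a hetero atom and one of carbon only, bearing a methoxy group, therefore cannot be told apart at this place in this assay. The only step beyond the scatter remains the one at the amine, a 19-fold lower number from compound 2 to compound 3 (1.29 log units; beyond the scatter), and no measurement shown offers an explanation for either outcome.

Among the compounds shown here, whether the gain in that amine step carries over to compounds with pyridin-3-yl or 2-methoxyphenyl on the carbonyl carbon remains open, since no measured pair tests the amine change with either group in place. Also open, on these data alone, is how a plain phenyl, a pyridin-4-yl or a 4-methoxyphenyl on the carbonyl carbon, or a morpholine in place of the amine, would read in this assay.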